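The compounds below may be only part of what the source reports. "The series", "measured", "known", "first", "only" and "open" are said of these compounds alone.

In an ADME assay on L02 cells (Homo sapiens) for inhibition, read by CCK-8 assay, with a stated time of 48 h (a higher number here means a weaker inhibitor of growth, a lower number a stronger inhibitor of growth), compound 1 `CN1CCN(c2ccc(Nc3ncc(Cl)c(Nc4ccccc4)n3)nc2)CC1` gives 7990 nM with phenyl on the nitrogen, and compound 2 `CN1CCN(c2ccc(Nc3ncc(Cl)c(NCc4ccccc4)n3)nc2)CC1` gives 20300 nM with benzyl there. Compound 3 `Cc1ccc(CNc2nc(Nc3ccc(N4CCN(C)CC4)cn3)ncc2Cl)cc1` reports only a limit of the assay at > 100000 nM and no number. Compound 4 `CN1CCN(c2ccc(Nc3ncc(Cl)c(NCc4ccc(F)cc4)n3)nc2)CC1` carries fluoro in place of methyl on an aromatic carbon and so turns 4-methylbenzyl into 4-fluorobenzyl. The closest measured change is methyl in place of hydrogen on an aromatic carbon, an at least 4.9-fold higher number from compound 2 to compound 3 (0.69 log units; beyond the scatter) which is at least modest. With that methyl gone, a modest step to a lower number is expected in this assay toward compound 2 at 20300 nM in this series. The estimated step is an at least 2.5-fold lower number from compound 3 to compound 4 (0.39 log units; beyond the scatter) on this reading. For compound 4 the expected value is 40000 nM with an estimated span from 15000 nM to 100000 nM as its range.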

Compound 4, concentration for 50% growth inhibition: 39700 nM
The estimate for compound 4 lay 1.0-fold (0.00 log units) above the measured number; measured number inside the range.
By their numbers in this assay, from the lowest: compound 1; then compounds 2 and 4 (each within the scatter of the next). At a limit, above all of these: compound 3.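

Taking the methyl off the 4-methylbenzyl group for fluoro brings the number back from the limit (an at least 2.5-fold lower number from compound 3 to compound 4 (0.40 log units; beyond the scatter)), while fluoro in place of hydrogen on the benzyl group stays within the scatter (a 2.0-fold higher number from compound 2 to compound 4 (0.29 log units; within the scatter)), so the rise seen with methyl does not appear with fluoro. The 4-fluorobenzyl group still stands apart from phenyl (a 5.0-fold higher number from compound 1 to compound 4 (0.70 log units; beyond the scatter)) in this assay. Compound 3 remains a limit of the assay, so its step gives only a bound: the limit of > 100000 nM in this assay, at which 1 of the 4 values shown sits.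

From the compounds shown here alone, whether an ethyl, a methoxy or an amine at this carbon follows methyl or fluoro stays open. So does how chloro there would compare.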